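A few compounds are considered here, and "the series" means these few. Any claim that something is new, unique, unknown or untested is made for them only; others in the source may bear on it.

Measured in a functional assay on HeLa cells (Homo sapiens) for cytotoxicity, in the presence of a further agent that is not named here; on this read-out higher numbers stand for weaker inhibition and lower numbers for stronger inhibition:
compound 1 `Clc1ccc(-c2cc(-c3cccs3)nc(-c3ccccc3Cl)c2)o1` — compound 1 gives 18500 nM
compound 2 `Clc1ccc(-c2cc(-c3ccoc3)cc(-c3ccsc3)n2)cc1` — compound 2 gives 4140 nM
compound 3 `Clc1ccc(-c2cc(-c3ccsc3)nc(-c3ccccn3)c2)o1` — compound 3 gives 22500 nM

Compound 3 stands at the highest of the three numbers. Its value and that of compound 1 lie within the scatter of one another, so nothing separates the two; the number of compound 2 lies lower than that of compound 3 by more than the scatter.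

Compound 4 `Clc1ccc(-c2cc(-c3ccsc3)nc(-c3ccco3)c2)o1` is not yet measured. It differs from compound 3 in one place: furan-2-yl in place of pyridin-2-yl on an aromatic carbon. Going by the values given here, no measured pair shows this change, so there is no precedent. Compound 1 carries another group at that place and gives 18500 nM, within the scatter of compound 3, which suggests the read-out may tolerate changes there. The expected step of a 1.5-fold lower number from compound 3 to compound 4 (0.18 log units; within the scatter) is small, toward a lower number, and not clearly beyond the scatter. Compound 4 is estimated at 15000 nM, with a range from 5000 nM to 45000 nM.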

Compound 4, half-maximal inhibitory concentration: > 50000 nM
Compound 4 gave a limit, no number; the forecaster's own chance of this, stated with the estimate: 15%; middle value at least 3.3-fold (0.52 log units) from the limit.
By their numbers in this assay, from the lowest: compound 2; then compounds 1 and 3 (each within the scatter of the next). At a limit, above all of these: compound 4.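

In this assay, the place next to the ring nitrogen now has its first measured one-place change, and the read-out responds to it: furan-2-yl in place of pyridin-2-yl gives an at least 2.2-fold higher number from compound 3 to compound 4 (0.34 log units; beyond the scatter). Compound 4 gives a limit of the assay, not a number: the limit of > 50000 nM in this assay, at which 1 of the 4 values shown sits. From the compounds shown here alone, the full size of this step therefore stays unknown.

One swap cannot show whether the step follows from losing pyridin-2-yl or from introducing furan-2-yl. Going by these compounds, how an amine or a carboxylic acid at this place would read out remains open.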